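Lipophilicity notes: from compound 2 to compound 4

The compounds below may be only part of what the source reports. "The series", "measured", "known", "first", "only" and "open" are said of these compounds alone.

Measured in a physicochemical assay for lipophilicity, at pH 7.4; a higher number here means a more lipophilic compound, a lower number a more polar compound:
- Compound 1 `Cc1cc(C)c(CN2CCc3c(Cl)cc([C@H](CO)[C@H]4CCOC4)c(Cl)c3C2=O)c(=O)[nH]1` gives 2
- Compound 2 `COc1cc(C)[nH]c(=O)c1CN1CCc2c(Cl)cc(-c3c(C)noc3C)c(Cl)c2C1=O` gives 2.7
- Compound 3 `CCOC(c1cc(Cl)c2c(c1Cl)C(=O)N(Cc1c(C)cc(C)[nH]c1=O)CC2)C1CS(=O)(=O)C1` gives 2.4; 2.3 (2 entries)

Of the two single numbers, the higher belongs to compound 2 at 2.7 and the lower to compound 1 at 2, a gap beyond the usual scatter. For compound 3 there is no single number, only (the several entries of compound 3 in this assay, 2.4; 2.3 (2 entries)).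

Compound 4 `COc1cc(C)[nH]c(=O)c1CN1CCc2c(Cl)cc([C@@H](O)C3COC3)c(Cl)c2C1=O` differs from compound 2 in one group, on an aromatic carbon ortho to a chloro group: a group of 6 heavy atoms (4 carbon, 2 oxygen; one four-membered non-aromatic ring with 1 hetero atom) in place of a group of 7 heavy atoms (5 carbon, 1 nitrogen, 1 oxygen; one five-membered aromatic ring with 2 hetero atoms), on an aromatic carbon. Among the compounds with values here, no step between measured compounds isolates this change, so the expectation rests on compound 1, which gives 2 and also carries a non-aromatic ring holding oxygen on that carbon, though its remaining structure is not identical.

The estimated step of a number 0.80 log units lower from compound 2 to compound 4 (beyond the scatter) is expected to be downward and beyond the scatter in this assay. In this assay compound 4 is expected at 1.9 within an estimated range of 1.4 to 2.4 as the working figure.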

Compound 4, distribution coefficient: 1.3
Estimate against measurement, compound 4: 0.60 log units above; the whole stated range lies above it.
By their numbers in this assay, from the lowest: compound 4; then compound 1; then compound 2.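

In this assay, within the data shown here, the replacement of 3,5-dimethyl-1,2-oxazol-4-yl by the group of compound 4 gives a number 1.40 log units lower from compound 2 to compound 4 (beyond the scatter) as the first step that isolates a change in one place. Compound 1, compound 2 and compound 3 differ from one another in more than one place, so they could not show what this aromatic carbon, ortho to a chloro group, contributes on its own. The repeat entries for compound 3 are the only supporting data on hand, and they do not bear on the size of this step.

As far as these compounds go, the step changes the ring type and the hydrogen-bond donor count together, so the share of each remains open. Also open, from the compounds shown here alone, is where an amine, a carboxylic acid or a longer alkyl chain on this carbon would fall in this assay within the same series.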